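Lengthening the ester chain of compound 3

The source may hold more compounds than are shown below. What is called first, only, known or untested is meant among the compounds shown, and "the series" means these compounds.

Compound 1 `CCCCC1([C@@H](O)/C=C/C2CCC(=O)[C@@H]2CCCCCCC(=O)OCC)CCC1` gives 0.032 mg/kg
Compound 2 `CCCCC1([C@H](O)/C=C/C2CCC(=O)[C@@H]2C/C=C\CCCC(=O)O)CCC1` gives 0.0022 mg/kg
Compound 3 `CCCCC1([C@H](O)/C=C/C2CCC(=O)[C@@H]2CCCCCCC(=O)OCC)CCC1` gives 0.0151 mg/kg

In a functional assay on the whole organism (strain Hartley) for inhibition, with Cavia porcellus as the target, with stated times of 15 min and 2 min (a lower number here means that less compound is needed, a higher number that more compound is needed for the effect), compound 3 gives 0.0151 mg/kg, the second highest of the three numbers. On either side of it, compound 1 gives 0.032 mg/kg and compound 2 gives 0.0022 mg/kg.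

Compound 4 `CCCCC1([C@H](O)/C=C/C2CCC(=O)[C@@H]2CCCCCCCCC(=O)OCC)CCC1` changes compound 3 in one place, on a saturated chain carbon, six bonds along the chain from a saturated ring carbon: 2-(ethoxycarbonyl)ethyl in place of ethoxycarbonyl on a saturated chain carbon, six bonds along the chain from a saturated ring carbon. Within the data shown here, no measured pair changes the length of this chain. Among the measured compounds shown here, the one measured step, a 2.1-fold lower number from compound 1 to compound 3 (0.33 log units; beyond the scatter), goes with a difference in configuration, as the fact that one of compounds 1 and 3 is drawn with a defined configuration and the other without, at the place where they differ shows, so it bears on the new change only as a rough guide to size. A modest step toward a higher number is therefore expected, although no measurement supports that direction. The estimated step is a 2.6-fold higher number from compound 3 to compound 4 (0.42 log units; beyond the scatter). For compound 4 the expected value is 0.04 mg/kg, with an estimated range from 0.01 mg/kg to 0.15 mg/kg.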

Compound 4, dose for half-maximal effect: 6.21 mg/kg
For compound 4 the middle estimate is 160-fold (2.19 log units) below the measured one, and the stated range ends below it.
By their numbers in this assay, from the lowest: compound 2; then compound 3; then compound 1; then compound 4.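

The length of this chain proved decisive in this assay: 2-(ethoxycarbonyl)ethyl in place of ethoxycarbonyl gives a 410-fold higher number from compound 3 to compound 4 (2.61 log units; beyond the scatter). Among these compounds, until now the only step on record was the one in configuration, a 2.1-fold lower number from compound 1 to compound 3 (0.33 log units; beyond the scatter), and the change in chain length is far larger, so this position is much less forgiving of added length than the earlier compounds could show. Nothing among the available evidence bears on why the longer chain has this effect.

The compounds shown do not tell whether the rise is gradual or abrupt, as (ethoxycarbonyl)methyl at this place would help to show. They also leave open whether a longer chain ending in a carboxylic acid instead of the ethyl ester would carry the same penalty.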